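A saturated ring in place of the chloromethylphenyl tail

This account rests on a few compounds, and the source may have more. Where it says the series, first, only, none or still open, it means among the compounds named here.

Two compounds have been measured in an assay for inhibition of 15-hydroxyprostaglandin dehydrogenase [NAD(+)] (Homo sapiens), read by fluorescence and spectrophotometry; on this read-out higher numbers stand for weaker inhibition and lower numbers for stronger inhibition:

- compound 1 `Cc1ncsc1CCOc1ccc(/C=C2\SC(O)=NC2=O)cc1`: 636 nM
- compound 2 `O=C1N=C(O)S/C1=C\c1ccc(OCc2ccc(CCl)cc2)cc1`: 124 nM

Within the data shown here, compound 2 gives the lowest number of the two; its only neighbour is compound 1, and the step of a 5.1-fold lower number from compound 1 to compound 2 (0.71 log units; beyond the scatter) lies beyond the scatter. Compound 3 `CC1CCC(COc2ccc(/C=C3\SC(O)=NC3=O)cc2)CC1` keeps the core of compound 2 and differs from it in one place: 4-methylcyclohexyl in place of 4-(chloromethyl)phenyl on a saturated chain carbon bound to an oxygen on an aromatic ring. Among the measured compounds shown here, the single measured step, a 5.1-fold lower number from compound 1 to compound 2 (0.71 log units; beyond the scatter), swapped one group for another at this same saturated chain carbon, and the chloromethylphenyl group that entered there is the one that now leaves. For the measured compounds named here, no measured pair shows an aromatic ring giving way to a saturated one, so the step has no close precedent. Compound 3 is estimated at 280 nM, within 90 nM to 900 nM, an expected change of a 2.3-fold higher number from compound 2 to compound 3 (0.35 log units; beyond the scatter).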

Compound 3, half-maximal inhibitory concentration: 52 nM
Beside the measured number, compound 3's estimate is 5.4-fold (0.73 log units) above it, and the stated range ends above it.
By their numbers in this assay, from the lowest: compound 3; then compound 2; then compound 1.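

In this assay, this saturated chain carbon bound to an oxygen on an aromatic ring does not need an aromatic ring in its tail: 4-methylcyclohexyl in place of 4-(chloromethyl)phenyl gives a 2.4-fold lower number from compound 2 to compound 3 (0.38 log units; beyond the scatter). Measured against the tail of compound 1, the same group gives a 12-fold lower number from compound 1 to compound 3 (1.09 log units; beyond the scatter), which makes compound 3 the strongest inhibitor of the three. Nothing available here bears on why the saturated ring gives the lower number.

The step from compound 2 to compound 3 changes the ring and removes the chlorine together, so a 4-methylphenyl tail would be needed to separate those two changes. On these data alone, it also remains open whether the methyl on the cyclohexyl ring contributes, which an unsubstituted cyclohexyl or a piperidine ring carrying a ring amine could test.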